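The source may hold more compounds than are shown below. What is called first, only, known or untested is meant among the compounds shown, and "the series" means these compounds.

In a functional assay on HCT-116 cells (Homo sapiens) for inhibition (a higher number here means a weaker inhibitor, a lower number a stronger inhibitor), compound 1 (`COc1ccc(/C=C/c2ccc3ccccc3c2)cc1`) gives > 5000 nM, which is a limit of the assay and not a number. Compound 2 (`Cc1ccc(/C=C/c2ccc3ccccc3c2)cc1`) also gives only a limit, > 5000 nM. Compound 3 (`CN(C)c1ccc(/C=C/c2ccc3ccccc3c2)cc1`) gives an actual number, 3660 nM. Compound 1 therefore stands at the limit of > 5000 nM in this assay, at which 2 of the 3 values shown sit.

Compound 4 (`COc1ccc(/C=C/c2ccc3ccccc3c2)cc1[N+](=O)[O-]`) keeps the core of compound 1 and carries nitro in place of hydrogen on an aromatic carbon, ortho to a methoxy group: nitro in place of hydrogen on an aromatic carbon.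

Going by the values given here, no measured step adds a nitro group, so the evidence is indirect. The nearest steps exchange one group on an aromatic carbon for another. Methyl in place of methoxy gives a step that the two limits leave unreadable from compound 1 to compound 2. Dimethylamino in place of methoxy gives an at least 1.3-fold lower number from compound 1 to compound 3 (0.13 log units; that floor lies within the scatter). Dimethylamino in place of methyl gives an at least 1.3-fold lower number from compound 2 to compound 3 (0.13 log units; that floor lies within the scatter). None of these is shown to exceed the scatter, so no step beyond the scatter is expected in this assay, and no direction can be predicted. The expected change is a step that the limit leaves unreadable from compound 1 to compound 4. For compound 4 the estimated value is 6000 nM, with an expected range from 1500 nM to 20000 nM.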

Compound 4, half-maximal inhibitory concentration: > 5000 nM
Compound 4: only a limit was reported; the forecaster's own chance of this, stated with the estimate: 60%; the middle value does not contradict the limit.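

Compound 1 and compound 4 both give only a limit and not a number, so no step between them can be read: the limit of > 5000 nM in this assay, at which 3 of the 4 values shown sit.

Going by these compounds, whether nitro in place of hydrogen makes compound 4 a stronger or weaker inhibitor than compound 1, or changes nothing, stays open.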